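This account rests on a few compounds, and the source may have more. Where it says the series, first, only, none or still open, it means among the compounds named here.

Among the measured compounds shown here, compound 2 `COc1ccc(OCCc2ccccc2)c(CCCNC(C)=O)c1` gives 2930 nM in an assay on CHO cells for displacement of a labelled ligand from melatonin receptor type 1A (Homo sapiens), read by scintillation counting, with a stated time of 60 min (a lower number here means a stronger inhibitor, a higher number a weaker inhibitor), the higher of the two numbers so far. For the measured compounds named here, compound 1 `CCCOc1ccc(OC)cc1CCCNC(C)=O` gives 400 nM in this assay, and the step of a 7.3-fold higher number from compound 1 to compound 2 (0.86 log units; beyond the scatter) is the only measured step in the set. Compound 3 `COc1ccc(OCc2ccccn2)c(CCCNC(C)=O)c1` differs from compound 2 by pyridin-2-yl in place of benzyl on a saturated chain carbon bound to an oxygen on an aromatic ring. The measured step bears on this only loosely: it concerned a different chain carbon, and there a phenyl entering raised the number. Going by the values given here, because compound 2 with its benzyl stands at 2930 nM while compound 1 with a shorter, ring-free chain stands at 400 nM, compound 3, whose chain is shortened and carries an acceptor, is expected to move back toward compound 1, so the step of a 2.9-fold lower number from compound 2 to compound 3 (0.47 log units; beyond the scatter) is expected to be a lower number, though the one step is a thin basis. The estimate for compound 3 is 1000 nM, within 300 nM to 3500 nM.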

Compound 3, inhibition constant: 1840 nM
Estimate against measurement, compound 3: 1.8-fold (0.26 log units) below; the measured number falls inside the stated range.
By their numbers in this assay, from the lowest: compound 1; then compounds 3 and 2 (each within the scatter of the next).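

In this assay, pyridin-2-yl in place of benzyl on a saturated chain carbon bound to an oxygen on an aromatic ring gives a 1.6-fold lower number from compound 2 to compound 3 (0.20 log units; within the scatter), so swapping this carbon-only ring for one holding a nitrogen and a hydrogen-bond acceptor, read further out as phenethyl to (pyridin-2-yl)methyl, leaves no difference that can be told from the scatter. The gap to the ring-free chain of compound 1 remains, with a 4.6-fold higher number from compound 1 to compound 3 (0.66 log units; beyond the scatter), so both ring-bearing compounds stand on the same side of compound 1. No measurement at hand explains these numbers.

Going by these compounds, it remains open whether the ring or the chain length sets this gap, a question on which a plain phenyl on this same carbon would bear. On these data alone, how pyridin-3-yl, or a chain ending in an amine, would read at this position is equally open.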